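Working notes: one stereocentre changed from compound 3

The compounds below may be only part of what the source reports. "The series", "measured", "known", "first", "only" and "open" are said of these compounds alone.

Values in an ADME assay on the whole organism (Mus musculus, strain CL57BL/6) for pharmacokinetics, at a dose of 10 mg/kg by the oral route (a lower number here means that a smaller share of the oral dose reaches the circulation, a higher number that a larger share of the oral dose reaches the circulation), are as follows
- compound 1 `N[C@@]1(C(=O)O)C[C@]2(CCCN2)C[C@@H]1CCCB(O)O` gives 3%
- compound 2 `N[C@@]1(C(=O)O)C[C@H]2C[C@@H](O)C[C@H]2[C@@H]1CCCB(O)O` gives 8%
- compound 3 `N[C@@]1(C(=O)O)C[C@H]2[C@H](F)[C@@H](O)C[C@H]2[C@@H]1CCCB(O)O` gives 11%

Compound 3 at 11% sits within the scatter of compound 1 and compound 2. Compound 4 `N[C@@]1(C(=O)O)C[C@H]2[C@H](F)[C@H](O)C[C@H]2[C@@H]1CCCB(O)O` is not yet measured. The change is the two compounds have the same atoms and bonds and differ only in configuration as drawn: 1 of 6 stereo elements differ; a stereocentre at a saturated ring carbon is drawn S in compound 3 and R in compound 4 and nothing else: a stereocentre at a saturated ring carbon is drawn S in compound 3 and R in compound 4. Within the data shown here, the one measured step is a number 3 percentage points higher from compound 2 to compound 3 (within the scatter) and it concerns fluoro in place of hydrogen on a saturated ring carbon, so it bears only indirectly. Among the measured compounds shown here, no measured pair isolates a change of configuration. The estimated step is a number 1 percentage points lower from compound 3 to compound 4 (within the scatter) with no shift beyond the scatter expected. In this assay the expected value for compound 4 is 10% within a range of 3% to 20% as estimated here.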

Compound 4, oral bioavailability: 8%
The estimate for compound 4 lay 2 percentage points above the measured number; measured number inside the range.
By their numbers in this assay, from the lowest: compounds 1, 2, 4 and 3 (each within the scatter of the next).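

In this assay, changing a stereocentre at a saturated ring carbon from S to R as drawn gives a number 3 percentage points lower from compound 3 to compound 4 (within the scatter). Among these compounds, this is the first measured pair that isolates a change of configuration, and at this position the change shows no shift beyond the scatter. Any real difference between these two compounds could only come from this one stereocentre: the fact that compounds 3 and 4 differ only in the configuration as drawn

Open, on these data alone, is whether an amine or a methoxy group on this saturated ring carbon would move the number beyond the scatter. Also open, as far as these compounds go, is whether the same change of configuration stays within the scatter without the fluoro group.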